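The compounds below may be only part of what the source reports. "The series", "measured", "known", "first", "only" and "open" are said of these compounds alone.

Working notes on the series. The measure used throughout is an assay on MCF7 cells for inhibition of Steryl-sulfatase (Homo sapiens), read by scintillation counting, with a stated time of 5 h, tested at 1 uM; a lower number here means a weaker effect, a higher number a stronger effect of the compound at the concentration tested. Compound 1 `NS(=O)(=O)Oc1ccc(Cc2ccc(OS(N)(=O)=O)cc2)cc1` carries two sulfamoyloxy groups on its core and gives 50.1%. Compound 3 `CCCC(CCC)(c1ccc(OS(N)(=O)=O)c(C)c1)c1ccc(OS(N)(=O)=O)c(C)c1` also carries two sulfamoyloxy groups and gives 21.1%. Compound 2 `C[Si](C)(c1ccc(O)cc1)c1ccc(O)cc1` carries no sulfamoyl group at all, and in this assay compound 2 reports only a limit, < 10%. That is where compound 2 stands: at the bottom of the values shown, on the line described by the limit of < 10% in this assay, at which 1 of the 3 values shown sits, with no number of its own.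

The step to compound 4 `C[Si](C)(c1ccc(O)cc1)c1ccc(OS(N)(=O)=O)cc1` is sulfamoyl in place of hydrogen on an oxygen on an aromatic ring, putting a single sulfamoyl into a compound that had none. Among the compounds with values here, both compounds that hold sulfamoyl groups, compound 1 and compound 3, return numbers in this assay while compound 2 does not; the step is therefore expected to run upward, and by more than the scatter, though with only one sulfamoyl in place compound 4 is not expected to reach the reading of compound 1. The estimated step from compound 2 to compound 4 is a number at least 20 percentage points higher from compound 2 to compound 4 (beyond the scatter). Compound 4 is estimated at 30%, with a range from 12% to 50%.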

Compound 4, a percentage reported as inhibition, at one concentration (the size of the read-out at that concentration, not a potency): 76.4%
Estimate against measurement, compound 4: 46.4 percentage points below; the measured number lies above the stated range.
By their numbers in this assay, from the lowest: compound 3; then compound 1; then compound 4. At a limit, below all of these: compound 2.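

In this assay, sulfamoyl in place of hydrogen on an oxygen on an aromatic ring gives a number at least 66.4 percentage points higher from compound 2 to compound 4 (beyond the scatter). Within the data shown here, the earlier compounds offered no pair differing in one place, so this is the first direct reading of the change: hydroxy to sulfamoyloxy at this single position, with the other hydroxy left in place, is enough to lift the read-out clear of the limit. The step is a bound rather than an exact size because compound 2 has no number of its own: the limit of < 10% in this assay, at which 1 of the 4 values shown sits.

The compounds shown leave open whether a second sulfamoyloxy in place of the remaining hydroxy of compound 4 would move the reading. Also open, as far as these compounds go, is whether another group on that oxygen, such as acetyl or methanesulfonyl, would give a comparable step.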